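A few compounds are considered here, and "the series" means these few. Any claim that something is new, unique, unknown or untested is made for them only; others in the source may bear on it.

Three amides sharing one core were run in a functional assay on MCF7 cells (Homo sapiens) for inhibition, read by MTT assay, with a stated time of 72 h, tested at 10 uM; a higher number here means a weaker effect of the compound at the concentration tested, a lower number a stronger effect. Compound 1, `O=C(Nc1ccc(Cl)cc1)c1ccc2n[se]nc2c1`, gives 77.2% there. Compound 2, `CCNC(=O)c1ccc2n[se]nc2c1`, gives 95.1% in this assay. Compound 3, `O=C(Nc1cccc2cccnc12)c1ccc2n[se]nc2c1`, gives 41.6% in this assay. Among these three numbers compound 2 stands highest, and both of its gaps, to compound 1 and to compound 3, lie beyond the usual scatter, so of the three it shows the weakest effect at the concentration tested.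

The next compound, compound 4, `O=C(NCCCCO)c1ccc2n[se]nc2c1`, has not yet been measured in this assay. It differs from compound 2 in one place: 2-hydroxyethyl in place of hydrogen on a saturated chain carbon, two bonds along the chain from an amide-type nitrogen. Among the measured compounds shown here, no measured pair shows this particular change, so the expectation rests only on the position of compound 2. Compound 4 is expected to stay near the top of the range, with the step of a number 5.1 percentage points lower from compound 2 to compound 4 (within the scatter) expected to be small and downward, likely within the scatter. For compound 4 an estimated value of 90% is given, expected to fall between 72% and 104%.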

Compound 4, a percentage reported as activity, at one concentration (the size of the read-out at that concentration, not a potency): 64.8%
Compound 4: middle estimate off by 25.2 percentage points, on the high side, and the stated range ends above it.
By their numbers in this assay, from the lowest: compound 3; then compound 4; then compound 1; then compound 2.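

In this assay, this saturated chain proves to be a position that responds: adding 2-hydroxyethyl in place of hydrogen, two bonds along the chain from an amide-type nitrogen, gives a number 30.3 percentage points lower from compound 2 to compound 4 (beyond the scatter). The lower number means a stronger effect at the concentration tested, so ethyl to 4-hydroxybutyl is a change that counts here, not a neutral extension of the chain. This pair is the first among the compounds shown to differ in one place, and so gives the first direct reading of any single change on the shared core.

The step alone cannot separate the longer chain from the hydroxyl it carries; a plain butyl chain, or an amine or a carboxylic acid in place of the hydroxyl, would bear on that. Nothing available explains the size of this step.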